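Dimethylamino for chloro: cytotoxicity outlook for compound 4

The source may report more compounds than this note shows. Statements on the series, on what has been measured and on what is new or still open speak of the compounds shown alone.

Three members of the series have been measured in an ADME assay on H9 cells (Homo sapiens) for cytotoxicity, read by MTT assay, with a stated time of 7 days; a lower number here means that less compound is tolerated, a higher number that more compound is tolerated. Compound 1 `COc1ccccc1C(=O)Nc1nc(Cl)ncc1Sc1ccc([N+](=O)[O-])cc1` gives 480000 nM. Compound 2 `COc1ccccc1NC(=O)c1cc(F)ccc1Sc1ccc([N+](=O)[O-])cc1` gives 502000 nM, and compound 3 `COc1ccccc1NC(=O)c1cc(Cl)ccc1Sc1ccc([N+](=O)[O-])cc1` gives 483000 nM. All three numbers lie within the usual scatter of one another, so compound 3 cannot be told apart from compound 1 or from compound 2 on this read-out. Among the measured compounds shown here, the single step available between measured compounds, a 1.0-fold lower number from compound 2 to compound 3 (0.02 log units; within the scatter), is a chloro in place of fluoro on an aromatic carbon and stays within the scatter.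

Compound 4 `COc1ccccc1NC(=O)c1cc(N(C)C)ccc1Sc1ccc([N+](=O)[O-])cc1` differs from compound 3 in one place: dimethylamino in place of chloro on an aromatic carbon. For the measured compounds named here, no measured step involves a dimethylamino group, so nothing bears directly on this change; the only precedent at the same place is the chloro-for-fluoro step, which moved nothing. The expectation in this assay is therefore no step beyond the scatter, in neither direction, with a wide range to reflect the lack of precedent. Compound 4 is estimated at 480000 nM, between 240000 nM and 960000 nM, which amounts to an expected 1.0-fold lower number from compound 3 to compound 4 (0.00 log units; within the scatter).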

Compound 4, half-maximal cytotoxic concentration: 182000 nM
Beside the measured number, compound 4's estimate is 2.6-fold (0.42 log units) above it, outside the stated range (below it).
By their numbers in this assay, from the lowest: compound 4; then compounds 1, 3 and 2 (each within the scatter of the next).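

In this assay, this place, meta to a large group and para to a large group, is now shown to move the read-out: dimethylamino in place of chloro gives a 2.7-fold lower number from compound 3 to compound 4 (0.42 log units; beyond the scatter) and dimethylamino in place of fluoro gives a 2.8-fold lower number from compound 2 to compound 4 (0.44 log units; beyond the scatter) on the same core. Fluoro and chloro remain within the scatter of each other here, so of the three groups shown at this place only dimethylamino stands apart, on the side of less compound tolerated. No data on hand account for this shift.

Going by these compounds, whether the shift belongs to dimethylamino alone or extends to other nitrogen substituents stays open, since a primary amine, a pyrrolidine or an acetamide at this place would separate those readings. On these data alone, whether the same change carries over to the core of compound 1 also remains unknown.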